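The source may hold more compounds than are shown below. What is called first, only, known or untested is meant among the compounds shown, and "the series" means these compounds.

In a functional assay on U-937 cells (Homo sapiens) for antiproliferative activity, read by MTT assay, with a stated time of 72 h (on this read-out lower numbers stand for stronger inhibition and higher numbers for weaker inhibition), compound 1 `Cc1ccc(-c2noc(CCCCCCC(=O)C(F)(F)F)n2)cc1` gives 3730 nM and compound 2 `O=C(CCCCCCc1nc(-c2ccc(F)cc2)no1)C(F)(F)F` gives 2350 nM. Among the measured compounds shown here, these are the only two numbers available, and they lie within the scatter of each other, so compound 2 does not stand clearly apart from compound 1. The next compound, compound 3 `O=C(CCCCCCc1nc(-c2ccc([N+](=O)[O-])cc2)no1)C(F)(F)F`, keeps the rest of compound 2 and changes one group: nitro in place of fluoro on an aromatic carbon. In words, this is nitro in place of fluoro on an aromatic carbon, para to a large group.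

For the measured compounds named here, one measured step bears on this change, made at the same aromatic carbon with fluoro in place of methyl: a 1.6-fold lower number from compound 1 to compound 2 (0.20 log units; within the scatter). That step stayed within the scatter. It is a single step, however, and nitro has not yet been tested in this series, so the evidence is thin and the range must stay wide. The expected change is a 1.1-fold higher number from compound 2 to compound 3 (0.03 log units; within the scatter), which means no step beyond the scatter and no favoured direction in this assay. For compound 3 the estimate is 2500 nM, with an expected range from 1000 nM to 6000 nM.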

Compound 3, half-maximal inhibitory concentration: 3680 nM
Compound 3: the middle estimate sits 1.5-fold (0.17 log units) below what was measured; the measured number falls inside the stated range.
By their numbers in this assay, from the lowest: compounds 2, 3 and 1 (each within the scatter of the next).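

On this aromatic carbon, para to a large group, nitro in place of fluoro gives a 1.6-fold higher number from compound 2 to compound 3 (0.19 log units; within the scatter) in this assay, and nitro in place of methyl gives a 1.0-fold lower number from compound 1 to compound 3 (0.01 log units; within the scatter). Among the compounds shown here, the single earlier step showed only that fluoro and methyl could not be told apart here, whereas these steps extend that result to a third group: nitro brings three heavy atoms and two hydrogen-bond acceptors in place of the single fluorine, and the number still stays within the scatter, so the three compounds cannot be placed in a meaningful order. No measurement at hand offers an explanation for this flat result.

On these data alone, it remains open whether a quite different group at this same carbon, such as an amine or a carboxylic acid, would produce a step beyond the scatter. Also unresolved is whether a change elsewhere in the molecule, such as a shorter or longer chain leading to the carbonyl, would affect the number more than these swaps on the aromatic ring have done.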